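Swapping the phenoxy tail for a trifluoromethoxy group

The source may hold more compounds than are shown below. What is called first, only, known or untested is meant among the compounds shown, and "the series" means these compounds.

Compound 1 `O=C(c1ccc(C#Cc2ccc(Oc3ccccc3)cc2)cc1)N1CCC[C@@H](CO)C1` carries a phenoxy group on the far aromatic ring of an alkyne-linked benzamide. In a functional assay on TREX cells for negative allosteric modulation of metabotropic glutamate receptor 3 (Rattus norvegicus), read by calcium flux, with a stated time of 2.5 min (a higher number here means a weaker inhibitor, a lower number a stronger inhibitor), compound 1 gives > 10000 nM, which is a limit of the assay and not a number. Two related compounds with a methoxy group on that ring have been measured: compound 2 `COc1ccc(C#Cc2ccc(C(=O)N3CCC[C@@H](O)C3)cc2F)cc1` gives 456 nM; 457 nM (2 entries) in this assay, with close agreement across its repeats (the several entries of compound 2 in this assay, 456 nM; 457 nM (2 entries)), and compound 3 `COc1ccc(C#Cc2ccc(C(=O)N3CC4CCC(O)C4C3)cc2)cc1` gives 5500 nM. For the measured compounds named here, both differ from compound 1 in the amide part as well, so no single step connects them to it; their values only show that a small alkoxy group on that ring is compatible with measurable inhibition, whereas compound 1 sits at the limit (the limit of > 10000 nM in this assay, at which 1 of the 3 values shown sits).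

Compound 4 `O=C(c1ccc(C#Cc2ccc(OC(F)(F)F)cc2)cc1)N1CCC[C@@H](CO)C1` makes one change to compound 1: trifluoromethyl in place of phenyl on an oxygen on an aromatic ring. Given that the small-alkoxy compounds give numbers while compound 1 does not, a gain in potency is expected, and compound 4 is estimated at 2500 nM, most likely between 600 nM and 10000 nM, a step of an at least 4.0-fold lower number from compound 1 to compound 4 (0.60 log units; beyond the scatter) beyond the scatter.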

Compound 4, half-maximal inhibitory concentration: > 10000 nM
Compound 4 gave a limit, no number (the forecaster's own chance of this, stated with the estimate: 25%); at least 4.0-fold (0.60 log units) between middle value and limit.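

Compound 1 and compound 4 both end at a limit of this assay and not at a number, and the step between them cannot be read. The compounds shown leave open how far past that limit each lies, and whether phenoxy and trifluoromethoxy differ at all.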